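The source may report more compounds than this note shows. Statements on the series, on what has been measured and on what is new or still open speak of the compounds shown alone.

Measured in a functional assay on the whole organism (Tail) for activation, with Mus musculus as the target, with a stated time of 1 min; on this read-out lower numbers stand for an effect already at smaller amounts and higher numbers for an effect only at larger amounts of compound:
- Compound 1 `O=C1NC(=O)N(/N=C/c2ccc(-c3ccc(Cl)cc3)o2)C1O`: > 1000 mg/kg
- Compound 2 `CC(=O)Nc1ccc(-c2ccc(/C=N/N3C(=O)NC(=O)C3O)o2)cc1`: > 1000 mg/kg
- Compound 3 `O=C1NC(=O)N(/N=C/c2ccc(-c3cccc(C(F)(F)F)c3)o2)C1O`: > 1000 mg/kg

Each of these entries is a limit of the assay and not a number. Compound 2 therefore has no exact position, only its limit of > 1000 mg/kg. The next compound is compound 4 `O=C1NC(=O)N(/N=C/c2ccc(-c3ccc([N+](=O)[O-])cc3)o2)C1O`, in which nitro takes the place of acetamido on an aromatic carbon: nitro in place of acetamido on an aromatic carbon.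

For the measured compounds named here, the one measured step that bears on this change is a step that the two limits leave unreadable from compound 1 to compound 2, where acetamido replaced chloro on an aromatic carbon. It offers neither a size nor a direction. Compound 1, compound 2 and compound 3 share (the limit of > 1000 mg/kg in this assay, at which 3 of the 3 values shown sit), so the series gives no sign of a step beyond the scatter in this assay, and none is expected here. The step expected is a step that the limit leaves unreadable from compound 2 to compound 4, with no direction foreseen. A report as a limit is the likeliest outcome. For compound 4 the estimated value is 1500 mg/kg, with an expected range of 600 mg/kg to 4000 mg/kg.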

Compound 4, dose for half-maximal effect: > 1000 mg/kg
Compound 4: a limit, no number; the forecaster's own chance of this, stated with the estimate: 80%; the middle value is on the limit's open side.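

In this assay compound 4 gives > 1000 mg/kg, a limit of the assay and not a number, so the steps to it from compound 1 and compound 2 cannot be read. The four compounds stand alike: the limit of > 1000 mg/kg in this assay, at which 4 of the 4 values shown sit. What they leave open is how their doses for half-maximal effect compare.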